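A few compounds are considered here, and "the series" means these few. Any claim that something is new, unique, unknown or untested is made for them only; others in the source may bear on it.

The measured compounds:
Compound 1, `CNC(=O)/C=C/c1ccncc1-c1ccc2cc[nH]c2c1`, gives > 10000 nM, a limit of the assay.
Compound 2, `Cn1ccc2cc(-c3cnccc3/C=C/C(=O)O)ccc21`, gives > 10000 nM, a limit of the assay.
Compound 3, `O=C(O)/C=C/c1ccncc1-c1ccc2cc[nH]c2c1`, gives > 10000 nM, a limit of the assay.

All three were tested in a functional assay on KB cells (Homo sapiens) for inhibition, read by sulforhodamine B assay, with a stated time of 72 h; on this read-out higher numbers stand for weaker inhibition of growth and lower numbers for stronger inhibition of growth. None of them gave a number: every value sits at the limit of > 10000 nM in this assay, at which 3 of the 3 values shown sit. Compound 1 is made from compound 3 by one change, (methylamino in place of hydroxy on a carbonyl carbon), and the step that the two limits leave unreadable from compound 3 to compound 1; with both ends at the limit, nothing can be said about its size. Compound 2 carries a different core from compound 3; the difference between the two cores is not broken down here. Compound 4, `CNC(=O)/C=C/c1ccncc1-c1ccc2c(ccn2C)c1`, is not yet measured. It differs from compound 2 by methylamino in place of hydroxy on a carbonyl carbon, the same change, at the same place, as from compound 3 to compound 1. Going by the values given here, because compound 2 gives > 10000 nM and the one comparable step is unreadable, the expected step is a step that the limit leaves unreadable from compound 2 to compound 4 in this assay. Compound 4 is estimated at 15000 nM, between 5000 nM and 50000 nM, and most likely the assay will again report only its limit.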

Compound 4, concentration for 50% growth inhibition: 7080 nM
Estimate against measurement, compound 4: 2.1-fold (0.33 log units) above; measured number inside the range.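

On the core of compound 2, putting methylamino in place of hydroxy on a carbonyl carbon gives, in this assay, an at least 1.4-fold lower number from compound 2 to compound 4 (0.14 log units; that floor lies within the scatter). Compound 2 gives > 10000 nM, which is a limit of the assay and not a number, so the true step could be larger, but the floor alone does not show a change beyond the usual scatter. The same change on the core of compound 3 cannot be read, so these compounds do not show that its effect carries from one core to the other, nor whether its size would match, since both ends of that step sit at the limit: the limit of > 10000 nM in this assay, at which 3 of the 4 values shown sit.

Going by these compounds, it remains open what an unsubstituted amino group, a dimethylamino group or a longer chain such as ethylamino would give in place of methylamino on the core of compound 4. On these data alone, it is also open whether any of these groups would bring the core of compound 1 to a readable number.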